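Aryl exchange on the saturated ring carbon

A few compounds are considered here, and "the series" means these few. Any claim that something is new, unique, unknown or untested is made for them only; others in the source may bear on it.

In an ADME assay on Vero 76 cells (Chlorocebus sabaeus) for cytotoxicity, read by MTT assay, with a stated time of 96 h (a higher number here means that more compound is tolerated, a lower number that less compound is tolerated), compound 1 (`NS(=O)(=O)c1ccc(N2N=C(c3ccc(OCc4ccccc4)cc3)CC2c2ccc(F)cc2)cc1`) gives 90000 nM and compound 2 (`Cc1ccc(C2CC(c3ccc(OCc4ccccc4)cc3)=NN2c2ccc(S(N)(=O)=O)cc2)cc1`) gives 100000 nM. Within the data shown here, these are the only two numbers so far, and they lie within the scatter of each other, so compound 2 cannot be separated from compound 1.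

Compound 3 (`NS(=O)(=O)c1ccc(N2N=C(c3ccc(OCc4ccccc4)cc3)CC2c2cccc(Cl)c2)cc1`) carries 3-chlorophenyl in place of 4-methylphenyl on a saturated ring carbon, next to the ring nitrogen: 3-chlorophenyl in place of 4-methylphenyl on a saturated ring carbon. Among the measured compounds shown here, only one measured step bears on this, a 1.1-fold higher number from compound 1 to compound 2 (0.05 log units; within the scatter), for methyl in place of fluoro on an aromatic carbon. For the measured compounds named here, no measured compound carries 3-chlorophenyl, so this support is thin. No step beyond the scatter is expected in this assay, and no direction is favoured. The expected step is a 1.3-fold lower number from compound 2 to compound 3 (0.10 log units; within the scatter). Compound 3 is estimated at 80000 nM, with an expected range of 40000 nM to 100000 nM.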

Compound 3, half-maximal cytotoxic concentration: 85000 nM
The estimate for compound 3 lay 1.1-fold (0.03 log units) below the measured number; low and high end bracket the measured number.
By their numbers in this assay, from the lowest: compounds 3, 1 and 2 (each within the scatter of the next).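

Earlier compounds covered only methyl in place of fluoro at one place on the phenyl group; compound 3 changes both the substituent and where it stands on that phenyl group. In this assay, 3-chlorophenyl on the saturated ring carbon gives a 1.2-fold lower number from compound 2 to compound 3 (0.07 log units; within the scatter) and a 1.1-fold lower number from compound 1 to compound 3 (0.02 log units; within the scatter), so 4-methylphenyl, 4-fluorophenyl and 3-chlorophenyl cannot be separated at this position. Nothing at hand explains this result.

The compounds shown carry only a phenyl group with a single chloro, fluoro or methyl substituent at this carbon. From the compounds shown here alone, whether a phenyl group bearing an amine or a carboxylic acid, or a longer chain in place of the phenyl group, would move the number in this assay beyond the scatter remains open.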